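A Chlorophenyl Group Replaces Pentyl on a Weakly Cytotoxic Core

The source may report more compounds than this note shows. Statements on the series, on what has been measured and on what is new or still open speak of the compounds shown alone.

Compound 1 `Cc1nnc2nnc(N3CCCC3)nn12`: 29700 nM
Compound 2 `C1CCC(c2nnc3nnc(N4CCCC4)nn23)CC1`: 23800 nM
Compound 3 `CCCCCc1nnc2nnc(N3CCCC3)nn12`: 42500 nM

These three compounds share one core and were tested in a functional assay on HL-60 cells (Homo sapiens) for cytotoxicity, read by MTT assay, with a stated time of 72 h; a lower number here means a stronger inhibitor, a higher number a weaker inhibitor. Compound 3 stands at the highest of the three numbers, yet the steps leading to it are small: a 1.4-fold higher number from compound 1 to compound 3 (0.16 log units; within the scatter) and a 1.8-fold higher number from compound 2 to compound 3 (0.25 log units; within the scatter), and the remaining pair shows a 1.2-fold lower number from compound 1 to compound 2 (0.10 log units; within the scatter). All three therefore sit within the scatter of one another, and none can be called stronger or weaker than the rest.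

Compound 4 `Clc1ccccc1-c1nnc2nnc(N3CCCC3)nn12` differs from compound 3 in one place: 2-chlorophenyl in place of pentyl on an aromatic carbon. Among the compounds with values here, none of the measured steps brings an aromatic ring into this place; the nearest comparison is the exchange of a saturated ring for a chain, a 1.8-fold higher number from compound 2 to compound 3 (0.25 log units; within the scatter), which stayed within the scatter, and the methyl-to-ring change, a 1.2-fold lower number from compound 1 to compound 2 (0.10 log units; within the scatter), which did likewise. On that basis compound 4 is expected to remain near the measured cluster in this assay, with no step beyond the scatter. The estimate for compound 4 is 30000 nM, with a range of 10000 nM to 90000 nM. This expected value corresponds to a step of a 1.4-fold lower number from compound 3 to compound 4 (0.15 log units; within the scatter).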

Compound 4, half-maximal inhibitory concentration: 2660 nM
Compound 4: the middle estimate sits 11-fold (1.05 log units) above what was measured; the whole stated range lies above it.
By their numbers in this assay, from the lowest: compound 4; then compounds 2, 1 and 3 (each within the scatter of the next).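

In this assay, methyl, cyclohexyl and pentyl on this aromatic carbon of the five-membered ring gave no step beyond the scatter, whereas 2-chlorophenyl does so against all three: a 16-fold lower number from compound 3 to compound 4 (1.20 log units; beyond the scatter), an 8.9-fold lower number from compound 2 to compound 4 (0.95 log units; beyond the scatter) and an 11-fold lower number from compound 1 to compound 4 (1.05 log units; beyond the scatter). Within the data shown here, the place is therefore not indifferent to what it carries, as the earlier compounds had suggested. The cyclohexyl group of compound 2 shows that a saturated ring does not produce this step, while nothing at hand explains why the aromatic group does.

The compounds shown cannot separate the contribution of the aromatic ring from that of its chlorine, as a plain phenyl group is not among them. As far as these compounds go, whether fluorine or methoxy could stand in for the chlorine also remains open.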